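Ortho-to-meta chlorine shift on the benzyl sulfide: series notes

This account rests on a few compounds, and the source may have more. Where it says the series, first, only, none or still open, it means among the compounds named here.

Compound 1 `COc1ccc(C2N=C(SCc3ccccc3Cl)NC(C)=C2C(=O)Nc2ccc(Br)cc2)cc1` and compound 2 `COc1ccc(C2N=C(SCc3cccc(Cl)c3)NC(C)=C2C(=O)Nc2ccc(Br)cc2)cc1` share one core and differ only at the benzyl group on sulfur; the change is 3-chlorophenyl in place of 2-chlorophenyl on a saturated chain carbon bound to a sulfur. In a functional assay on the whole organism (artery, strain albino) with Rattus norvegicus as the target, with a stated time of 30 min, at a dose of 10 mg/kg by the oral route (a higher number here means more inhibition at the dose given (going by the name of the read-out), a lower number less inhibition), compound 1 gives 4.6%, and compound 2 gives 7.7%, so the change made a number 3.1 percentage points higher from compound 1 to compound 2 (within the scatter).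

Compound 3 `CC1=C(C(=O)Nc2ccc([N+](=O)[O-])cc2)C(c2ccc(Br)cc2)N=C(SCc2ccccc2Cl)N1` carries a different core; the difference between the two cores is not broken down here. In this assay compound 3 gives 3.6%, which sits within the scatter of both compound 1 and compound 2.

Compound 4 `CC1=C(C(=O)Nc2ccc([N+](=O)[O-])cc2)C(c2ccc(Br)cc2)N=C(SCc2cccc(Cl)c2)N1` is not yet measured. It is built from compound 3 by 3-chlorophenyl in place of 2-chlorophenyl on a saturated chain carbon bound to a sulfur, the same change as that between compound 1 and compound 2, at the same place. Among the measured compounds shown here, with no second core that carries this change measured, the only guide is the step from compound 1 to compound 2, which was within the scatter. The step from compound 3 to compound 4 in this assay is therefore expected to be small, about a number 2.4 percentage points higher from compound 3 to compound 4 (within the scatter), resting on that earlier step and on compound 3 at 3.6%. Compound 4 is estimated at 6% in this assay, with a range from 0% to 14%.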

Compound 4, a percentage reported as inhibition, in the whole organism at one dose (the size of the read-out at that dose, not a potency): 2.6%
Beside the measured number, compound 4's estimate is 3.4 percentage points above it; measured number inside the range.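

In this assay, 3-chlorophenyl in place of 2-chlorophenyl on the core of compound 3 gives a number 1 percentage points lower from compound 3 to compound 4 (within the scatter). Set beside the earlier step, the change gives no reading on either core that stands clear of the scatter, and the two steps cannot be told apart: the same change on two cores in this assay, a number 3.1 percentage points higher (within the scatter) from compound 1 to compound 2 and a number 1 percentage points lower (within the scatter) from compound 3 to compound 4, 4.1 percentage points apart, within the scatter of two such steps. This shows that carrying the change from one core to the other produced no step beyond the scatter, but it does not show that the change is without effect or that the two cores respond alike, and a real effect smaller than the scatter would not be seen in these two pairs.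

The compounds shown leave open whether a different group in place of the chlorine on the benzyl sulfide, such as an amine or a carboxylic acid, would give a step beyond the scatter. Also open, going by these compounds, is whether the two chlorobenzyl isomers would separate at another dose or time.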